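Branching the hydroxamic acid linker of compound 1

The compounds below may be only part of what the source reports. "The series", "measured", "known", "first", "only" and "open" are said of these compounds alone.

Compound 1 `O=C(CCCOc1no[n+]([O-])c1S(=O)(=O)c1ccccc1)NO` carries a hydroxamic acid on a short chain that hangs from an oxygen on the shared core. Among the measured compounds shown here, in a functional assay on HCT-116 cells (Homo sapiens) for inhibition, read by MTT assay, with a stated time of 48 h (on this read-out higher numbers stand for weaker inhibition and lower numbers for stronger inhibition), compound 1 gives 3830 nM, the highest of the two numbers measured so far. Its closest neighbour is compound 2 `O=C(CCCCCCCOc1no[n+]([O-])c1S(=O)(=O)c1ccccc1)NO`, which in this assay gives 2610 nM; the step of a 1.5-fold lower number from compound 1 to compound 2 (0.17 log units; within the scatter) shows that lengthening the chain by a 4-(hydroxycarbamoyl)butyl group changes little.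

Compound 3 `CC(C)(COc1no[n+]([O-])c1S(=O)(=O)c1ccccc1)C(=O)NO` has not yet been measured. Relative to compound 1 the change is 1-(hydroxycarbamoyl)-1-methylethyl in place of 2-(hydroxycarbamoyl)ethyl on a saturated chain carbon bound to an oxygen on an aromatic ring: the 2-(hydroxycarbamoyl)ethyl group leaves and a 1-(hydroxycarbamoyl)-1-methylethyl group enters, so the chain becomes one carbon shorter and gains two methyl groups on the carbon that bears the hydroxamic acid. For the measured compounds named here, the only measured step bearing on the linker, from compound 1 to compound 2, stayed within the scatter, and no measured pair tests branching. The step of a 1.1-fold higher number from compound 1 to compound 3 (0.04 log units; within the scatter) is therefore expected to be small, with no clear direction beyond the scatter. Compound 3 is estimated at 4200 nM, within a range from 1500 nM to 12000 nM.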

Compound 3, half-maximal inhibitory concentration: 9740 nM
Beside the measured number, compound 3's estimate is 2.3-fold (0.37 log units) below it; the range from low to high includes it.
By their numbers in this assay, from the lowest: compounds 2 and 1 (each within the scatter of the next); then compound 3.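

In this assay, the change at this saturated chain carbon gives a 2.5-fold higher number from compound 1 to compound 3 (0.41 log units; beyond the scatter), a modest step towards weaker inhibition that lies beyond the scatter. Lengthening the linker gave only a 1.5-fold lower number from compound 1 to compound 2 (0.17 log units; within the scatter), which stayed within the scatter, so this is the first change among the compounds shown that clearly moves the number, and the linker is therefore not free to vary in every way. The data shown offer nothing that explains this rise.

Replacing 2-(hydroxycarbamoyl)ethyl with 1-(hydroxycarbamoyl)-1-methylethyl alters the chain length and adds branching in a single step, so the compounds shown cannot say which of the two matters, or whether both do. An unbranched hydroxycarbamoylmethyl group would match the chain length of compound 3 without its branching, while a 1-(hydroxycarbamoyl)ethyl group, with a single methyl, would test a smaller degree of branching, and these two groups could begin to separate the effects.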